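This account rests on a few compounds, and the source may have more. Where it says the series, first, only, none or still open, it means among the compounds named here.

Compound 1, with the structure `Cc1ccc(NS(=O)(=O)c2ccc(N3CCNC3=O)cc2)cc1`, gives 260 nM in a functional assay on M21 cells (Homo sapiens) for antiproliferative activity, read by sulforhodamine B assay, with a stated time of 48 h; on this read-out higher numbers stand for weaker inhibition and lower numbers for stronger inhibition. Among the three compounds measured so far it stands highest: compound 3, `Cc1ccc(NS(=O)(=O)c2ccc(N3CCNC3=O)cc2)c(C)c1`, gives 150 nM, and compound 2, `CCc1cccc(NS(=O)(=O)c2ccc(N3CCNC3=O)cc2)c1`, gives 82 nM. The steps between them are a 3.2-fold lower number from compound 1 to compound 2 (0.50 log units; beyond the scatter), a 1.7-fold lower number from compound 1 to compound 3 (0.24 log units; within the scatter) and a 1.8-fold higher number from compound 2 to compound 3 (0.26 log units; within the scatter), so only the change to compound 2 went beyond the scatter, and only modestly.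

Compound 4, `CCCCCCOc1ccc(NS(=O)(=O)c2ccc(N3CCNC3=O)cc2)cc1`, differs from compound 1 in one place: hexyloxy in place of methyl on an aromatic carbon. The nearest guide is the step from compound 1 to compound 3, where a methyl entering on an aromatic carbon of the same ring gave a 1.7-fold lower number from compound 1 to compound 3 (0.24 log units; within the scatter), within the scatter. The step from compound 1 to compound 2 shows that rearranging small alkyl groups on this ring moves the number only modestly. Among the compounds with values here, no measured compound carries an alkoxy group or a chain as long as hexyloxy, so the data give no direct precedent for it. She therefore expects a step of a 1.3-fold lower number from compound 1 to compound 4 (0.11 log units; within the scatter), within or only just beyond the scatter, in no firm direction, and estimates compound 4 at 200 nM, with a range from 60 nM to 700 nM.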

Compound 4, half-maximal inhibitory concentration: > 1000 nM
Compound 4: a limit, no number; the forecaster's own chance of this, stated with the estimate: 5%; middle value at least 5.0-fold (0.69 log units) from the limit.
By their numbers in this assay, from the lowest: compounds 2, 3 and 1 (each within the scatter of the next, the first and the last beyond it). At a limit, above all of these: compound 4.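

In this assay compound 4 gives > 1000 nM, which is a limit of the assay and not a number. Even so, hexyloxy in place of methyl on this aromatic carbon, para to a large group, gives an at least 3.8-fold higher number from compound 1 to compound 4 (0.58 log units; beyond the scatter); this is the only step shown that passes the scatter toward a higher number, whereas the steps among the small alkyl compounds stayed within the scatter or, as in a 3.2-fold lower number from compound 1 to compound 2 (0.50 log units; beyond the scatter), went the other way. The result therefore shows what compound 2 and compound 3 could not, that this position is not indifferent to the group it carries, and compound 4 stands alone in reaching the limit: the limit of > 1000 nM in this assay, at which 1 of the 4 values shown sits.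

The compounds shown leave open whether the oxygen or the length of the chain goes with this change, and a hexyl chain without oxygen, or a shorter alkoxy group such as methoxy or propoxy, would separate the two. They also leave open how groups of another kind, such as an amine or a carboxylic acid, would fare at this position.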